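Solubility notes: carboxy for cyclopropylsulfamoyl on the aryl ring

A few compounds are considered here, and "the series" means these few. Any claim that something is new, unique, unknown or untested is made for them only; others in the source may bear on it.

Measured so far:
- compound 1 `COc1ccc(-c2cc(-c3ccc(S(=O)(=O)NC4CC4)cc3)cnc2N)cn1`: 6.3 ug/mL
- compound 2 `COc1ccc(-c2cc(-c3ccc(S(C)(=O)=O)cc3C(F)(F)F)cnc2N)cn1`: 12.5 ug/mL

In a physicochemical assay for solubility, read by nephelometry, in phosphate buffer, measured as kinetic solubility, at pH 6.5 (a higher number here means a more soluble compound, a lower number a less soluble compound), compound 1 gives 6.3 ug/mL and compound 2 gives 12.5 ug/mL. Among the compounds with values here, the two numbers lie within the usual scatter of each other, so neither compound is set apart from the other on this assay; compound 1 and compound 2 simply mark the range seen so far, and no step between them can be read as real.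

Compound 3 `COc1ccc(-c2cc(-c3ccc(C(=O)O)cc3)cnc2N)cn1` has not yet been measured in this assay. Against compound 1 it differs in one place: carboxy in place of cyclopropylsulfamoyl on an aromatic carbon. Within the data shown here, no measured pair shows this change, so the size of the step has to be guessed from the change alone. Compound 3 is expected to move to a higher number than compound 1 in this assay, by a 6.3-fold higher number from compound 1 to compound 3 (0.80 log units; beyond the scatter), with the sign of the step more firmly expected than its size. The estimate for compound 3 is 40 ug/mL, with a range from 10 ug/mL to 150 ug/mL; an upper limit read rather than a number is possible.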

Compound 3, solubility: 6.3 ug/mL
For compound 3 the middle estimate is 6.3-fold (0.80 log units) above the measured one, outside the stated range (below it).
By their numbers in this assay, from the lowest: compounds 1, 3 and 2 (each within the scatter of the next).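

In this assay, within the data shown here, carboxy in place of cyclopropylsulfamoyl on an aromatic carbon gives no change at the digits printed from compound 1 to compound 3 (within the scatter), the first single-place step that can be read. At this position, on a six-membered aromatic ring of carbon only and para to a large group, a group of 7 heavy atoms with a three-membered ring and a group of 3 heavy atoms with no ring are not told apart by this read-out, so this one exchange, which removes the sulfur, the nitrogen and the ring, registers no difference beyond the scatter. Nothing else at hand bears on this result, and the step stands without an explanation.

As far as these compounds go, whether any group at this position can separate itself from these two stays open, and an aminomethyl group, a morpholine or a longer chain ending in a hydroxyl would each put that to the test. A single pair also leaves open whether the same exchange gives the same reading when the rest of the molecule differs from the core of compound 1.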